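A few compounds are considered here, and "the series" means these few. Any claim that something is new, unique, unknown or untested is made for them only; others in the source may bear on it.

Working notes on the amide substituent of the shared core. Compound 1 `CN1C[C@H](C(=O)Nc2ccccc2F)[C@@H](c2ccc(/C=C/C(=O)Nc3ccccc3N)cc2)C1` gives 67 mL/min/kg in an in vitro ADME assay on microsomes from liver (Mus musculus) for pharmacokinetics, read by LC-MS, with a stated time of 10 min, tested at 1 uM (a higher number here means faster removal of the compound, a lower number slower removal), the highest of the three numbers measured. Compound 2 `CN1C[C@H](C(=O)Nc2ccc(F)c(Br)c2)[C@@H](c2ccc(/C=C/C(=O)Nc3ccccc3N)cc2)C1` gives 43 mL/min/kg in this assay, and compound 3 `CN1C[C@H](C(=O)Nc2ccc(F)cc2F)[C@@H](c2ccc(/C=C/C(=O)Nc3ccccc3N)cc2)C1` gives 27 mL/min/kg. For the measured compounds named here, the steps within the set are a 1.6-fold lower number from compound 1 to compound 2 (0.19 log units; within the scatter), a 2.5-fold lower number from compound 1 to compound 3 (0.39 log units; beyond the scatter) and a 1.6-fold lower number from compound 2 to compound 3 (0.20 log units; within the scatter); each keeps an aryl group on the amide nitrogen and only varies its halogen pattern, and a 2.5-fold lower number from compound 1 to compound 3 (0.39 log units; beyond the scatter) is the only step beyond the scatter. Compound 4 `CN1C[C@H](C(=O)NC2CC2)[C@@H](c2ccc(/C=C/C(=O)Nc3ccccc3N)cc2)C1` is not yet measured. Going by the values given here, its change from compound 1 is cyclopropyl in place of 2-fluorophenyl on an amide-type nitrogen No measured step removes the aryl group or places a three-membered ring on the amide nitrogen, so none of the three steps bears directly on it; they show only that halogenated aryl variants stay within a modest span of compound 1. The expectation is therefore a step of uncertain size with a wide range. Compound 4 is estimated at 45 mL/min/kg in this assay, range 18 mL/min/kg to 110 mL/min/kg. That estimate means an expected 1.5-fold lower number from compound 1 to compound 4 (0.17 log units; within the scatter).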

Compound 4, clearance: 7 mL/min/kg
For compound 4 the middle estimate is 6.4-fold (0.81 log units) above the measured one, outside the stated range (below it).
By their numbers in this assay, from the lowest: compound 4; then compounds 3, 2 and 1 (each within the scatter of the next, the first and the last beyond it).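

Cyclopropyl on the amide nitrogen shifts the number in this assay further than any change of halogen pattern among the aryl amides: a 9.6-fold lower number from compound 1 to compound 4 (0.98 log units; beyond the scatter), alongside a 6.1-fold lower number from compound 2 to compound 4 (0.79 log units; beyond the scatter) and a 3.9-fold lower number from compound 3 to compound 4 (0.59 log units; beyond the scatter). The lower number holds from all three halogenated aryl groups, so at this position, in these compounds, swapping the aryl group for cyclopropyl counts for more than the halogen pattern on the aryl group. Nothing at hand gives a reason for this shift.

Still open, going by these compounds, is whether the lower number goes with the loss of the aromatic ring, with the smaller group or with the three-membered ring itself. An isopropyl, a cyclobutyl or a benzyl group on the amide nitrogen would help to separate these readings.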